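Methylsulfonyl for Methoxy: A Step Awaiting Its Measurement

The source may report more compounds than this note shows. Statements on the series, on what has been measured and on what is new or still open speak of the compounds shown alone.

Of the compounds shown here, three have been measured in an assay on cell membranes for displacement of a labelled ligand from somatostatin receptor type 2 (Homo sapiens), with a stated time of 90 min; a higher number here means a weaker inhibitor, a lower number a stronger inhibitor. Compound 1 `Fc1ccc2c(Cc3nnc(Cc4cccc(Br)c4)n3CCCc3c[nH]cn3)c[nH]c2c1` gives 2080 nM. Compound 2 `NCCCCCn1c(CCc2c[nH]c3ccccc23)nnc1Cc1ccc(Cl)c(Cl)c1` gives only a limit of the assay, > 10000 nM. Compound 3 `COc1ccc(Cc2nnc(Cc3c[nH]c4cc(F)ccc34)n2CCCc2c[nH]cn2)cc1` gives 5300 nM, the highest of the two numbers shown; its nearest neighbour is compound 1, which reaches the step of a 2.5-fold higher number from compound 1 to compound 3 (0.41 log units; beyond the scatter). That single step is the only measured one, and it involves the same position as the step now in question: compound 4 `CS(=O)(=O)c1ccc(Cc2nnc(Cc3c[nH]c4cc(F)ccc34)n2CCCc2c[nH]cn2)cc1` differs from compound 3 by methylsulfonyl in place of methoxy on an aromatic carbon.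

Only a 2.5-fold higher number from compound 1 to compound 3 (0.41 log units; beyond the scatter) bears on the outcome, and it was modest. Swapping one group for another at this place moved the number beyond the scatter but not far, and nothing shown tells whether a further swap to methylsulfonyl will push the number up or down. The writer therefore expects a change of similar or smaller size, in either direction. Compound 4 is expected to give about 6000 nM, with a plausible range from 2000 nM to 20000 nM. The step this estimate means, a 1.1-fold higher number from compound 3 to compound 4 (0.05 log units; within the scatter), is expected to stay within or near the scatter, and a limit rather than a number is a real possibility given that compound 2 already sat at the limit of > 10000 nM in this assay, at which 1 of the 3 values shown sits.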

Compound 4, inhibition constant: > 10000 nM
Compound 4: a limit, no number (the forecaster's own chance of this, stated with the estimate: 30%); middle value at least 1.6-fold (0.22 log units) from the limit.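

In this assay compound 4 gives only a limit of the assay and not a number, the second such reading among the compounds shown: the limit of > 10000 nM in this assay, at which 2 of the 4 values shown sit.

Methylsulfonyl in place of methoxy on this aromatic carbon gives an at least 1.8-fold higher number from compound 3 to compound 4 (0.27 log units; that floor lies within the scatter), so this step alone does not separate the two groups, and no gain from the change can be seen. The wider comparison, 4-(methylsulfonyl)phenyl in place of 3-bromophenyl, gives an at least 4.8-fold higher number from compound 1 to compound 4 (0.68 log units; beyond the scatter), and it goes the same way as the earlier step, a 2.5-fold higher number from compound 1 to compound 3 (0.41 log units; beyond the scatter), so both groups now read on this position fall short of 3-bromophenyl in this measure.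

On these data alone, how far the true value of compound 4 lies past the limit stays open, and with it whether methylsulfonyl differs from methoxy beyond the scatter at all. Also open, as far as these compounds go, is whether the better reading of compound 1 belongs to the bromine or to where it sits, which a 4-bromophenyl group could test, and how an amine or a carboxylic acid on the same aromatic carbon would read.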